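The source may report more compounds than this note shows. Statements on the series, on what has been measured and on what is new or still open speak of the compounds shown alone.

Measured so far in an in vitro ADME assay on microsomes from liver (Homo sapiens) for metabolic stability; a higher number here means that the compound lasts longer, a lower number that the compound disappears faster:
- compound 1 `COC[C@@H]1C[C@@H](C(=O)NC[C@H]2CCCO2)CN(Cc2nc(-c3ccccc3)oc2C)C1` gives 0.07 h
- compound 2 `Cc1oc(-c2ccccc2)nc1CN1CCC[C@@H](C(=O)NC[C@@H]2CCCO2)C1` gives 0.235 h
- compound 3 `COC[C@@H]1C[C@@H](C(=O)NCC2CCOCC2)CN(Cc2nc(-c3ccccc3)oc2C)C1` gives 0.0682 h

Compound 1 is second of the three numbers, within the scatter of compound 3 and beyond the scatter below compound 2. Next is compound 4 `COC[C@H]1C[C@@H](C(=O)NC[C@H]2CCCO2)CN(Cc2nc(-c3ccccc3)oc2C)C1` with the two compounds have the same atoms and bonds and differ only in configuration as drawn: 1 of 3 stereo elements differ; a stereocentre at a saturated ring carbon is drawn R in compound 1 and S in compound 4, a stereocentre at a saturated ring carbon being drawn R in compound 1 and S in compound 4. Going by the values given here, the only measured step from compound 1, a 1.0-fold lower number from compound 1 to compound 3 (0.01 log units; within the scatter), changes the amide side and leaves this stereocentre untouched, so it is a weak guide. Among the compounds with values here, no measured pair tests this inversion. No step beyond the scatter is therefore expected in this assay, and no direction is favoured. The expected step is a 1.1-fold higher number from compound 1 to compound 4 (0.06 log units; within the scatter), an estimate only. Compound 4 is estimated at 0.08 h (expected range 0.04 h to 0.18 h).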

Compound 4, half-life: 0.403 h
Compound 4: the middle estimate sits 5.0-fold (0.70 log units) below what was measured; the whole stated range lies below it.
By their numbers in this assay, from the lowest: compounds 3 and 1 (each within the scatter of the next); then compounds 2 and 4 (each within the scatter of the next).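

Inverting this saturated ring carbon from R to S gives a 5.8-fold higher number from compound 1 to compound 4 (0.76 log units; beyond the scatter) in this assay and so shows a sensitivity to configuration here that the earlier amide-side change did not show, that step being a 1.0-fold lower number from compound 1 to compound 3 (0.01 log units; within the scatter) in the same assay. The step can be tied to this stereocentre alone: the fact that compounds 1 and 4 differ only in the configuration as drawn.

On these data alone, whether the S configuration gives a similar step with the oxan-4-yl amide of compound 3 remains open. Also open, as far as these compounds go, is whether a hydroxymethyl group or a longer ether chain on this ring carbon would keep the longer half-life.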